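Trimming the Amide Side Chain of Compound 2

The compounds below may be only part of what the source reports. "The series", "measured", "known", "first", "only" and "open" are said of these compounds alone.

Compound 2 `O=C(CN1CCCC1)Nc1ccc(-c2nc3cc(C(F)(F)F)ccc3[nH]2)cc1` gives the lowest of the three numbers measured in an ADME assay on MT4 cells (Homo sapiens) for cytotoxicity, read by MTT assay, with a stated time of 96 h (a higher number here means that more compound is tolerated, a lower number that less compound is tolerated), at 18000 nM. Compound 1 `CC(=O)Nc1ccc(-c2nc3cc(C(F)(F)F)ccc3n2C2CCCCC2)cc1` gives 24000 nM in this assay, within the usual scatter of compound 2, while compound 3 `O=C(CN1CCCC1)Nc1ccc(-c2nc3ccccc3[nH]2)cc1` gives 40000 nM, a step of a 2.2-fold higher number from compound 2 to compound 3 (0.35 log units; beyond the scatter). Compound 4 `CCC(=O)Nc1ccc(-c2nc3cc(C(F)(F)F)ccc3[nH]2)cc1` is compound 2 altered in one place: methyl in place of pyrrolidin-1-yl on a saturated chain carbon bound to a carbonyl carbon. No measured step matches this change; the single step shown concerns a different part of the molecule. Compound 1 differs from compound 2 in more than one place, yet it also lacks pyrrolidin-1-yl and its number stays within the scatter. No step beyond the scatter is therefore expected from compound 2 to compound 4, namely a 1.2-fold higher number from compound 2 to compound 4 (0.09 log units; within the scatter). Compound 4 is estimated at 22000 nM in this assay, in a range from 10000 nM to 50000 nM.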

Compound 4, half-maximal cytotoxic concentration: >= 100000 nM
Compound 4 ended at the assay's limit; the forecaster's own chance of this, stated with the estimate: 10%; middle value at least 4.5-fold (0.65 log units) away from the limit.
By their numbers in this assay, from the lowest: compounds 2, 1 and 3 (each within the scatter of the next, the first and the last beyond it). At a limit, above all of these: compound 4.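

In this assay the swap of pyrrolidin-1-yl for methyl on a saturated chain carbon bound to a carbonyl carbon gives an at least 5.5-fold higher number from compound 2 to compound 4 (0.74 log units; beyond the scatter) and so shows that this side chain, which the earlier step on trifluoromethyl left untouched, can shift the tolerated concentration beyond the scatter. The value of compound 4 is a limit and not a number: the limit of >= 100000 nM in this assay, at which 1 of the 4 values shown sits.

Going by these compounds, the full size of this step therefore stays open. Also open is whether the ring or its nitrogen matters, since no compound shown carries an open-chain amine at this carbon.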